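The source may report more compounds than this note shows. Statements on the series, on what has been measured and on what is new or still open speak of the compounds shown alone.

Measured in a functional assay on MV4-11 cells (Homo sapiens) for antiproliferative activity, read by CCK-8 assay, with a stated time of 72 h; a lower number here means a stronger inhibitor, a higher number a weaker inhibitor:
compound 1 `Cc1cc(F)cc(C)c1Oc1ccc(C(C)(C)O)cc1-c1cn(C)c(=O)c2[nH]c(C(=O)NCc3ccc(C(=O)NO)cc3)cc12`: 440 nM
compound 2 `Cc1cc(F)cc(C)c1Oc1ccc(C(C)(C)O)cc1-c1cn(C)c(=O)c2[nH]c(C(=O)NCc3ccc(C(=O)Nc4ccccc4N)cc3)cc12`: 240 nM
compound 3 `Cn1cc(-c2ccccc2Oc2ccccc2)c2cc(C(=O)NCc3ccc(C(=O)NO)cc3)[nH]c2c1=O`: 570 nM

Compound 1 lies within the scatter of both other compounds, so its place among the three numbers gives it no separate rank. The next entry, compound 4 `CC(C)Oc1ccc(C(C)(C)O)cc1-c1cn(C)c(=O)c2[nH]c(C(=O)NCc3ccc(C(=O)NO)cc3)cc12`, alters one group of compound 1: isopropyl in place of 4-fluoro-2,6-dimethylphenyl on an oxygen on an aromatic ring.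

Among the measured compounds shown here, the only measured single-place step is a 1.8-fold lower number from compound 1 to compound 2 (0.26 log units; within the scatter), with 2-aminophenyl in place of hydroxy on an amide-type nitrogen. It lies within the scatter, but it concerns a different part of the molecule and gives no direct measure of the present change. Compound 3 differs from compound 1 in more than one place, yet it keeps a ring on that oxygen, and compound 3 reads 570 nM. For the measured compounds named here, no measured compound lacks that ring, so the data do not show what its removal does.

A small move to a higher number is expected in this assay, with wide uncertainty. The estimated change is a 1.4-fold higher number from compound 1 to compound 4 (0.13 log units; within the scatter). The estimate for compound 4 is 600 nM, with an expected range of 250 nM to 1400 nM.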

Compound 4, half-maximal inhibitory concentration: 350 nM
The estimate for compound 4 lay 1.7-fold (0.23 log units) above the measured number; low and high end bracket the measured number.
By their numbers in this assay, from the lowest: compounds 2, 4, 1 and 3 (each within the scatter of the next, the first and the last beyond it).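

Among the compounds shown here, the step of a 1.3-fold lower number from compound 1 to compound 4 (0.10 log units; within the scatter) is the first reading in this assay of a compound with no ring on the oxygen, since compound 1, compound 2 and compound 3 all carry one there. With that step inside the scatter, the 4-fluoro-2,6-dimethylphenoxy group, with its 9 heavy atoms on the aryl part, can give way to isopropoxy, with 3 carbon atoms and no ring, without a distinguishable difference in this pair, so a ring on that oxygen is not required for a reading of this size. No measured data given here bear on why the two groups read alike, and this single pair gives no trend across groups on the oxygen.

Open, from the compounds shown here alone, is how far this holds for other groups on that oxygen, such as a methyl, a longer chain such as n-butyl, a chain ending in an amine or a carboxylic acid, or a free hydroxy in place of the ether. Also open, going by these compounds, is whether isopropoxy reads the same when paired with the 2-aminophenyl amide of compound 2, and whether the match between these two groups extends beyond this assay.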